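One Hydroxy Fewer: From Compound 3 to Compound 4

The source may report more compounds than this note shows. Statements on the series, on what has been measured and on what is new or still open speak of the compounds shown alone.

Compound 1, `COc1ccc(/C=C/C(=O)c2ccc(OC)c(OC)c2)cc1O`, gives 5200 nM in a functional assay on A549 cells (Homo sapiens) for cytotoxicity, read by fluorescence, with a stated time of 48 h; a higher number here means a weaker inhibitor of growth, a lower number a stronger inhibitor of growth.
Compound 2, `COc1ccc(/C=C/C(=O)c2cc(OC)c(OC)c(OC)c2)cc1OCCN`, gives 5600 nM in this assay.
Compound 3, `COc1cc(C(=O)/C=C/c2ccc(O)c(O)c2)cc(OC)c1OC`, gives 2600 nM in this assay.

Of these three numbers, compound 3 has the lowest. The gap to compound 1 lies within the usual scatter of such measurements, so the two cannot be told apart; the gap to compound 2 lies just beyond it, so compound 3 does inhibit growth somewhat more strongly than compound 2.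

Compound 4, `COc1cc(C(=O)/C=C/c2cccc(O)c2)cc(OC)c1OC`, has not been measured. It differs from compound 3 in one place: hydrogen in place of hydroxy on an aromatic carbon. Among the measured compounds shown here, no pair of measured compounds shows this same change, so the size of the step has to be guessed. Losing a hydroxy group is expected to weaken growth inhibition a little, to a degree near the edge of the scatter. Compound 4 is therefore expected to give 5000 nM, within a range of 1500 nM to 16000 nM, which is an estimated step of a 1.9-fold higher number from compound 3 to compound 4 (0.28 log units; within the scatter).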

Compound 4, concentration for 50% growth inhibition: 1700 nM
Estimate against measurement, compound 4: 2.9-fold (0.47 log units) above; the range from low to high includes it.
By their numbers in this assay, from the lowest: compounds 4, 3, 1 and 2 (each within the scatter of the next, the first and the last beyond it).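

In this assay, the change from 3,4-dihydroxyphenyl to 3-hydroxyphenyl gives a 1.5-fold lower number from compound 3 to compound 4 (0.18 log units; within the scatter), so the two compounds cannot be told apart. Among the compounds shown here, this is the first direct look at this position, and it shows that this hydroxy group can be replaced by hydrogen with no measurable loss of growth inhibition. Nothing in the data shown explains this result.

What the one remaining hydroxy group contributes is still open, as no pair of compounds shown isolates its removal. Also open, from the compounds shown here alone, is whether a different group on the carbon that now carries hydrogen, such as a carboxylic acid or a fluorine atom, would shift the number beyond the usual scatter of such measurements.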